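Swapping the Acetylphenyl Arm for a Furan Ring

The source may hold more compounds than are shown below. What is called first, only, known or untested is meant among the compounds shown, and "the series" means these compounds.

Of the compounds shown here, three have so far been measured in an ADME assay (liver) for metabolic stability, with Liver microsome (Homo sapiens) as the target, read by LC-MS, using microsomes, tested at 1 uM; on this read-out higher numbers stand for fast clearance and lower numbers for slow clearance. Compound 1 `CNc1nc(NCCCN(C)C)c2sc(-c3ccc(-n4cccn4)cc3)cc2n1` gives 18.4 uL/min, and compound 2 `CNc1nc(NCCCN(C)C)c2sc(-c3ccc(C(F)(F)F)cc3)cc2n1` gives 14 uL/min. Compound 3 `CNc1nc(NCCCN(C)C)c2sc(-c3ccc(C(C)=O)cc3)cc2n1` gives 81 uL/min, the highest of the three, with a 4.4-fold higher number from compound 1 to compound 3 (0.64 log units; beyond the scatter) and a 5.8-fold higher number from compound 2 to compound 3 (0.76 log units; beyond the scatter) setting it apart. The new compound 4 `CNc1nc(NCCCN(C)C)c2sc(-c3ccoc3)cc2n1` differs from compound 3 by a single change (furan-3-yl in place of 4-acetylphenyl on an aromatic carbon). Among the compounds with values here, the steps that bear on this are the two leading into compound 3, each modest and beyond the scatter, and the change in compound 4 removes the acetyl group they introduced, so the number is expected to fall back toward those of compounds 1 and 2. Compound 4 is therefore expected to show a 3.2-fold lower number from compound 3 to compound 4 (0.51 log units; beyond the scatter), with an estimated value of 25 uL/min and a likely range from 10 uL/min to 60 uL/min.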

Compound 4, intrinsic clearance in a liver preparation (reported as CLH), per the amount of preparation that the assay uses: 33.3 uL/min
The estimate for compound 4 lay 1.3-fold (0.12 log units) below the measured number, and the stated range covers the measured number.
By their numbers in this assay, from the lowest: compounds 2, 1 and 4 (each within the scatter of the next, the first and the last beyond it); then compound 3.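

Exchanging the whole 4-acetylphenyl arm for the smaller furan-3-yl on the aromatic carbon next to the ring sulfur gives a 2.4-fold lower number from compound 3 to compound 4 (0.39 log units; beyond the scatter) in this assay. Until now only the group carried on the phenyl ring had changed, whereas this step shows that the number also moves when the phenyl ring itself is gone. Nothing measured here accounts for this shift. Still open, from the compounds shown here alone, is how an amine or a carboxylic acid at this position would read, and whether a furan-2-yl would match furan-3-yl.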